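The compounds below may be only part of what the source reports. "The series", "measured", "known", "first", "only" and "open" are said of these compounds alone.

Of the compounds shown here, two built on a related core have been tested in a functional assay on Malme-3M cells (Homo sapiens) for inhibition, read by sulforhodamine B assay, with a stated time of 48 h; on this read-out higher numbers stand for weaker inhibition of growth and lower numbers for stronger inhibition of growth. Compound 1, `N=C(N)c1ccc(-c2ccc(-c3cncc4ccccc34)s2)s1`, gives 1610 nM in this assay. Compound 2, `N=C(N)c1ccc(-c2ccc(-c3ccc(F)cc3)o2)o1`, gives 1630 nM in this assay. On these two numbers compound 2 stands close beside compound 1; the gap between them lies within the usual scatter of repeated measurements, so the two compounds cannot be told apart on what has been measured.

The next compound, compound 3, `N=C(N)c1ccc(-c2ccc(-c3ccc(Cl)cc3)o2)o1`, has not yet been measured. It differs from compound 2 in one place: chloro in place of fluoro on an aromatic carbon, para to a large group. Within the data shown here, no pair of measured compounds shows what such an exchange does here, so the direction of the step rests on the change alone. The step from compound 2 to compound 3 in this assay is expected to be small, a 1.4-fold lower number from compound 2 to compound 3 (0.13 log units; within the scatter), leaning toward a lower number and hardly beyond the scatter. Compound 3 is therefore expected to give about 1200 nM in this assay, within a range from 500 nM to 3000 nM.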

Compound 3, concentration for 50% growth inhibition: 1910 nM
Compound 3: the middle estimate sits 1.6-fold (0.20 log units) below what was measured, within the range that was stated.
By their numbers in this assay, from the lowest: compounds 1, 2 and 3 (each within the scatter of the next).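

In this assay, among these compounds, chloro in place of fluoro on an aromatic carbon, para to a large group, gives a 1.2-fold higher number from compound 2 to compound 3 (0.07 log units; within the scatter) and so provides the first single-place exchange that can be read directly. On this one pair, the two halogens cannot be told apart at this position, since any difference between them is no larger than what repeated measurements of the same compound would be expected to show. No measurement at hand offers a reason for this result.

From the compounds shown here alone, this single pair compares only two halogens, so it remains open whether a group of another kind at the same position, such as an amine, a carboxylic acid or a longer chain, would move the number beyond the scatter. Going by these compounds, it also remains open whether chloro in place of fluoro would give an equally small step elsewhere on this six-membered ring or on a different core.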